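The compounds below may be only part of what the source reports. "The series", "measured", "known", "first", "only" and "open" are said of these compounds alone.

Measured so far:
- Compound 1, `CCOc1ccccc1-n1nncc1CN1C(=O)C2(C(C#N)=C(N)Oc3c2c2nc4ccccc4nc2c2ccccc32)c2ccccc21`, in a functional assay on MCF7 cells (Homo sapiens) for antiproliferative activity, read by MTT assay, with a stated time of 48 h (a higher number here means a weaker inhibitor, a lower number a stronger inhibitor), gives only a limit, > 50000 nM.
- Compound 2, `Cc1ccc(Cl)cc1-n1nncc1CN1C(=O)C2(C(C#N)=C(N)Oc3c2c2nc4ccccc4nc2c2ccccc32)c2ccccc21`, in this assay gives only a limit, > 50000 nM.
- Compound 3, `CCc1ccccc1-n1nncc1CN1C(=O)C2(C(C#N)=C(N)Oc3c(N)cc4nc5ccccc5nc4c32)c2ccccc21`, in this assay gives 24600 nM.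

For the measured compounds named here, compound 3 thus holds the only number in this set; the other two values are limits, as stated in the limit of > 50000 nM in this assay, at which 2 of the 3 values shown sit.

The next compound, compound 4, `Cc1ccc(-n2nncc2CN2C(=O)C3(C(C#N)=C(N)Oc4c(N)cc5nc6ccccc6nc5c43)c3ccccc32)cc1C`, differs from compound 3 in one place: 3,4-dimethylphenyl in place of 2-ethylphenyl on an aromatic nitrogen.

Going by the values given here, only one measured step is available, a step that the two limits leave unreadable from compound 1 to compound 2. It also exchanges the aryl group on the same aromatic nitrogen, but with both ends at a limit its size cannot be read, so it gives no scale for the present change. Nothing measured therefore points to a step beyond the scatter in either direction, and the expectation for compound 4 rests on compound 3 alone, at 24600 nM, with a wide range.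

Compound 4 is estimated at 25000 nM, between 8000 nM and 50000 nM, an expected step of a 1.0-fold higher number from compound 3 to compound 4 (0.01 log units; within the scatter).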

Compound 4, half-maximal inhibitory concentration: > 50000 nM
Compound 4: a limit, no number; the forecaster's own chance of this, stated with the estimate: 35%; middle value at least 2.0-fold (0.30 log units) from the limit.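

For the compounds shown here, with compound 3 at one end, this exchange on the aromatic nitrogen gives the only step at this position with a readable floor: an at least 2.0-fold higher number from compound 3 to compound 4 (0.30 log units; that floor lies within the scatter). In this assay compound 4 gives only a limit, > 50000 nM. The leaving 2-ethylphenyl and the entering 3,4-dimethylphenyl match in every count computed for them, so that match does not guarantee a number rather than a limit here, and the limit now holds most of the set: the limit of > 50000 nM in this assay, at which 3 of the 4 values shown sit.

Going by these compounds, the true size of the step remains open, so it may lie within the scatter or well beyond it. Also open, on these data alone, is whether an aminomethyl or carboxylic acid group on the aryl ring at this nitrogen would give a number clearly lower than that of compound 3, 24600 nM.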